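Swapping butylamino for morpholin-4-yl on a carbonyl carbon

This account rests on a few compounds, and the source may have more. Where it says the series, first, only, none or still open, it means among the compounds named here.

Measured in a functional assay on MDA-MB-231 cells (Homo sapiens) for antiproliferative activity, read by MTT assay, with a stated time of 24 h; on this read-out lower numbers stand for stronger inhibition and higher numbers for weaker inhibition:
- Compound 1 `CCCCc1oc2ccccc2c1C(=O)c1ccc(OCC(=O)N[C@@H](C)c2ccccc2)cc1`: > 50000 nM (a limit of the assay)
- Compound 2 `CCCCNC(=O)CCCOc1ccc(C(=O)c2c(CCCC)oc3ccccc23)cc1`: 38100 nM

Among the measured compounds shown here, compound 2 holds the only true number in this small set, and that number is a high one, which on this read-out means weak inhibition. Compound 1 gives only a limit: the limit of > 50000 nM in this assay, at which 1 of the 2 values shown sits.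

The next compound, compound 3 `CCCCc1oc2ccccc2c1C(=O)c1ccc(OCCCC(=O)N2CCOCC2)cc1`, keeps compound 2 intact except for one group on its amide: morpholin-4-yl in place of butylamino on a carbonyl carbon. In words, morpholin-4-yl stands in place of butylamino on a carbonyl carbon.

For the measured compounds named here, only one measured step bears on this change. It also exchanges the group on the amide: an at least 1.3-fold lower number from compound 1 to compound 2 (0.11 log units; that floor lies within the scatter). Its floor lies within the scatter, so the data offer no sign that such exchanges move the number much, although a single step is thin evidence.

In this assay, no change beyond the scatter is therefore expected, and the expected step is a 1.2-fold higher number from compound 2 to compound 3 (0.07 log units; within the scatter).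

For compound 3 the estimated value is 45000 nM, with an expected range of 20000 nM to 80000 nM.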

Compound 3, half-maximal inhibitory concentration: 31600 nM
Compound 3: the middle estimate sits 1.4-fold (0.15 log units) above what was measured; low and high end bracket the measured number.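

In this assay, morpholin-4-yl can take the place of butylamino on this carbonyl carbon, with the hydrogen-bond donor of butylamino gone and a hydrogen-bond acceptor in the ring, and the result is a 1.2-fold lower number from compound 2 to compound 3 (0.08 log units; within the scatter). The comparison with the remaining compound also shows no change beyond the scatter, at an at least 1.5-fold lower number from compound 1 to compound 3 (0.19 log units; that floor lies within the scatter), though that step swaps more than the group on the amide. Compound 1 gives a limit and not a number: the limit of > 50000 nM in this assay, at which 1 of the 3 values shown sits.

The compounds shown leave open whether any group on this carbonyl carbon can bring the number down beyond the scatter, since the open-chain butylamino and the morpholine ring tell only of these two groups, and a piperazine ring or a simple dimethylamino group would test the position further. They also leave open what a longer chain ending in the same amide, or a carboxylic acid in place of the amide, would do in this assay.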